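Hydrogen for Methyl on Compound 2: What to Expect

This account rests on a few compounds, and the source may have more. Where it says the series, first, only, none or still open, it means among the compounds named here.

Measured so far:
compound 1 `COc1ccc(/C=C/C(=O)CC(C)=O)cc1OC` — 43100 nM
compound 2 `COc1cc(/C=C/c2cc(C)no2)ccc1O` — 34600 nM
compound 3 `CC(=O)/C=C(O)/C=C/c1ccc(O)c(O)c1` — 32200 nM

Of the compounds shown here, three have been tested in a functional assay on MDA-MB-231 cells (Homo sapiens) for cytotoxicity, read by MTT assay, with a stated time of 72 h; on this read-out higher numbers stand for weaker inhibition and lower numbers for stronger inhibition. Compound 1 `COc1ccc(/C=C/C(=O)CC(C)=O)cc1OC` gives 43100 nM in this assay, compound 2 `COc1cc(/C=C/c2cc(C)no2)ccc1O` gives 34600 nM, and compound 3 `CC(=O)/C=C(O)/C=C/c1ccc(O)c(O)c1` gives 32200 nM. Compound 2 lies between the other two, but its gap to compound 3 and its gap to compound 1 both fall within the usual scatter of repeated measurements, so the three numbers cannot be told apart and none of the compounds can be called more or less active than another.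

The next compound, compound 4 `Cc1cc(/C=C/c2ccc(O)c(O)c2)on1`, has not yet been measured in this assay. It differs from compound 2 in one place: hydrogen in place of methyl on an oxygen on an aromatic ring. Going by the values given here, no pair of measured compounds differs by this change alone, so there is no measured step to lean on. Since the three measured values all sit within the scatter of one another, the step from compound 2 to compound 4 is expected to be none beyond the scatter, that is a 1.1-fold lower number from compound 2 to compound 4 (0.05 log units; within the scatter). Compound 4 is therefore estimated to give about 31000 nM in this assay, with an expected range from 12000 nM to 75000 nM.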

Compound 4, half-maximal inhibitory concentration: 8900 nM
For compound 4 the middle estimate is 3.5-fold (0.54 log units) above the measured one; measured number below the stated range.
By their numbers in this assay, from the lowest: compound 4; then compounds 3, 2 and 1 (each within the scatter of the next).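

In this assay the change of methoxy to hydroxy gives a 3.9-fold lower number from compound 2 to compound 4 (0.59 log units; beyond the scatter), the only step shown so far and one that stands beyond the scatter. The earlier compounds shown here included no pair differing in one place, so they could not show that anything about their structures moved the read-out; this pair shows that replacing methyl with hydrogen on an oxygen on an aromatic ring does so, although the step is modest and rests on this single pair. Nothing in the material available explains why the compound carrying hydrogen at this place gives the lower number.

The compounds shown leave open how this oxygen would read with an ethyl group or an acetyl group on it, and how the aromatic ring would read with an amine in place of the hydroxy. They also leave open whether the same change would give a step of similar size on another core, such as the core of compound 1, which also carries methoxy groups.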